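From piperidine to morpholine on a carbonyl carbon

This account rests on a few compounds, and the source may have more. Where it says the series, first, only, none or still open, it means among the compounds named here.

In a functional assay on a cell-free system (Platelet, plasma, Homo sapiens) for inhibition, read by turbidimetry, with a stated time of 3 min (on this read-out lower numbers stand for stronger inhibition and higher numbers for weaker inhibition), compound 1 (`COc1ccc(-n2nc(C(=O)N3CCOCC3)cc2-c2ccc(Cl)cc2)nn1`) gives 83 nM as its half-maximal inhibitory concentration. Compound 2 (`COc1ccc(-n2nc(C(=O)N3CCCCC3)cc2C)nn1`) gives > 10000 nM and that is a limit, not a number. Compound 3 (`COc1ccc(-n2nc(C(=O)N3CCOCC3)cc2C)nn1`), not yet measured, has morpholin-4-yl in place of piperidin-1-yl on a carbonyl carbon. Among the measured compounds shown here, no measured step shows what this swap does, so the expected change is small, with no direction favoured and probably nothing beyond the scatter. The estimated step that the limit leaves unreadable from compound 2 to compound 3 is modest for that reason. For compound 3 the estimate is 12000 nM with an expected range from 3000 nM to 40000 nM and quite possibly only a limit again.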

Compound 3, half-maximal inhibitory concentration: > 10000 nM
Compound 3: a limit, no number; the forecaster's own chance of this, stated with the estimate: 70%; the middle value lies beyond the limit too.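

In this assay, methyl in place of 4-chlorophenyl on an aromatic carbon, with morpholin-4-yl kept, gives an at least 120-fold higher number from compound 1 to compound 3 (2.08 log units; beyond the scatter), which means much weaker inhibition, so this place on the shared core strongly shapes the result in this pair. The swap from piperidin-1-yl to morpholin-4-yl cannot be read, because compound 2 and compound 3 both give a limit rather than a number: the limit of > 10000 nM in this assay, at which 2 of the 3 values shown sit.

As far as these compounds go, whether piperidin-1-yl would match morpholin-4-yl with 4-chlorophenyl present remains open. So does how unsubstituted phenyl or ethyl would behave on that aromatic carbon.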